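Cyclohexyl Gives Way to Butyl: An Expected Whole-Organism Dose

The source may report more compounds than this note shows. Statements on the series, on what has been measured and on what is new or still open speak of the compounds shown alone.

Three compounds have so far been run through a functional assay on the whole organism for inhibition, with Cavia porcellus as the target, with a stated time of 2 h; on this read-out lower numbers stand for an effect already at smaller amounts and higher numbers for an effect only at larger amounts of compound. Compound 1 `COc1ccc(C(=C/C=C/C(=O)Nc2ccc(-c3cccnc3)cc2)c2ccc(OC)cc2)cc1` gives 29 mg/kg in this assay, compound 3 `COc1ccc(C(=C/C=C/C(=O)NC(C)(C)CCCc2cccnc2)c2ccc(OC)cc2)cc1` gives 55 mg/kg, and compound 2 `COc1ccc(/C(=C/C=C/C(=O)N[C@H](C)CCCc2cccnc2)C2CCCCC2)cc1` gives 10 mg/kg. Compound 2 thus stands at the lowest of the three numbers; its distance to compound 1 and its larger distance to compound 3 both lie beyond the usual scatter, so compound 2 acts at the smallest amount of the three.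

Compound 4 `CCCC/C(=C\C=C\C(=O)N[C@H](C)CCCc1cccnc1)c1ccc(OC)cc1` has not yet been measured in this assay. It differs from compound 2 in one place: butyl in place of cyclohexyl on a double-bonded chain carbon bound to an aromatic carbon and a double-bonded chain carbon. A cyclohexyl leaves and a butyl enters, on a double-bonded chain carbon bound to an aromatic carbon and a double-bonded chain carbon.

For the measured compounds named here, no pair of measured compounds differs in a single place, so nothing measured shows how a change at this position moves the dose. One therefore expects the step to be modest, a 1.5-fold higher number from compound 2 to compound 4 (0.18 log units; within the scatter), with no firm direction and quite possibly within the scatter. Compound 4 is accordingly estimated to give about 15 mg/kg in this assay, within a range from 6 mg/kg to 40 mg/kg.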

Compound 4, dose for 50% inhibition: 12 mg/kg
For compound 4 the middle estimate is 1.3-fold (0.10 log units) above the measured one; the measured number falls inside the stated range.
By their numbers in this assay, from the lowest: compounds 2 and 4 (each within the scatter of the next); then compounds 1 and 3 (each within the scatter of the next).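

For the compounds shown here, with this pair, a change at this position can be read on its own for the first time: in this assay butyl in place of cyclohexyl, on a double-bonded chain carbon bound to an aromatic carbon and a double-bonded chain carbon, gives a 1.2-fold higher number from compound 2 to compound 4 (0.08 log units; within the scatter) and so leaves the two compounds indistinguishable on this read-out. For this pair, then, the one six-membered non-aromatic ring of carbon only is not needed to keep the dose within the scatter of that of compound 2, and an open chain of 4 heavy atoms serves in place of the ring of 6. Nothing available explains why the two groups come out alike.

The compounds shown leave open whether a longer chain such as octyl, or a chain ending in an amine or a carboxylic acid, would also stay within the scatter of compound 2 at this position. Compound 1 and compound 3 differ from compound 2 and compound 4 in more than one place, so they do not show how a second aromatic ring compares with either group here.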